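The source may report more compounds than this note shows. Statements on the series, on what has been measured and on what is new or still open speak of the compounds shown alone.

Compound 1 `Nc1scc(-c2cccc(Cl)c2)c1C(=O)c1ccccc1`: 45%; compound 2 `Nc1scc(-c2ccc(Cl)cc2)c1C(=O)c1ccccc1`: 46%; compound 3 `Nc1scc(-c2cccc(Cl)c2)c1C(=O)c1ccc(Cl)cc1`: 58%.

The three compounds share one core and were measured in a functional assay on CHO cells for agonist activity at adenosine receptor A1 (Homo sapiens), read by fluorescence and ERK phosphorylation, with stated times of 30 min and 1.5 h, tested at 3 uM; a higher number here means a stronger effect of the compound at the concentration tested, a lower number a weaker effect. Compound 2 differs from compound 1 by 4-chlorophenyl in place of 3-chlorophenyl on an aromatic carbon, and the step of a number 1 percentage points higher from compound 1 to compound 2 (within the scatter) shows that this change left the read-out essentially where it was. Compound 3 differs from compound 1 by chloro in place of hydrogen on an aromatic carbon, and the step of a number 13 percentage points higher from compound 1 to compound 3 (beyond the scatter) is a modest rise; compound 3 gives the highest number of the three. Compound 4 `Nc1scc(-c2ccc(Cl)cc2)c1C(=O)c1ccc(Cl)cc1` has not yet been measured. It differs from compound 3 by 4-chlorophenyl in place of 3-chlorophenyl on an aromatic carbon, the same kind of change as that from compound 1 to compound 2, but on the core that differs as just described: in compound 3 the place is next to the ring atom that bears a group of 9 heavy atoms, in compound 1 next to one that bears a group of 8 heavy atoms. Since the earlier step of a number 1 percentage points higher from compound 1 to compound 2 (within the scatter) stayed within the scatter, a step of similar size is expected here, a number 1 percentage points higher from compound 3 to compound 4 (within the scatter). Compound 4 is therefore estimated at 59% in this assay, likely between 47% and 71%.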

Compound 4, a percentage reported as activity, at one concentration (the size of the read-out at that concentration, not a potency): 50%
Estimate against measurement, compound 4: 9 percentage points above; the measured number falls inside the stated range.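

In this assay, among the compounds shown here, placing 4-chlorophenyl where 3-chlorophenyl stood on the chlorinated core gives a number 8 percentage points lower from compound 3 to compound 4 (within the scatter), and this step cannot be told apart from the one seen earlier on the other core: the same change on two cores in this assay, a number 1 percentage points higher (within the scatter) from compound 1 to compound 2 and a number 8 percentage points lower (within the scatter) from compound 3 to compound 4, 9 percentage points apart, within the scatter of two such steps Chloro in place of hydrogen gives a number 4 percentage points higher from compound 2 to compound 4 (within the scatter), and this step also cannot be told apart from its earlier counterpart: the same change on two cores in this assay, a number 13 percentage points higher (beyond the scatter) from compound 1 to compound 3 and a number 4 percentage points higher (within the scatter) from compound 2 to compound 4, 9 percentage points apart, within the scatter of two such steps Neither change therefore shows a detectable dependence on the core, but two pairs of steps cannot prove that the changes are truly independent of it, and the rise from chloro stands beyond the scatter on only one of the two cores.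

The compounds shown leave open how the read-out would respond to a group other than chloro on the phenyl groups, such as methoxy or trifluoromethyl, or to an amide in place of the amino group. Each number comes from a single concentration and speaks only of a stronger or weaker effect at that concentration.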